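Swapping the Aryl Group on the Saturated Ring Carbon

The source may report more compounds than this note shows. Statements on the series, on what has been measured and on what is new or still open speak of the compounds shown alone.

Compound 1 `CN1C(=O)C(c2ccc(F)cc2)N(C)c2nc(Nc3ccc(S(N)(=O)=O)cc3)ncc21` is tested in an assay on Sf9 cells for inhibition of serine/threonine-protein kinase 4 (Homo sapiens), read by luminescence and ADP-Glo, with a stated time of 1 h, in the presence of a further agent that is not named here (a higher number here means a weaker inhibitor, a lower number a stronger inhibitor), where compound 1 gives 1770 nM. Among the three measured compounds this is the second highest number: compound 2 `CN1C(=O)C(c2cccc(C(F)(F)F)c2)N(C)c2nc(Nc3ccc(S(N)(=O)=O)cc3)ncc21` gives 2710 nM, while compound 3 `CCc1ccccc1C1C(=O)N(C)c2cnc(Nc3ccc(S(N)(=O)=O)cc3)nc2N1C` gives 51 nM. Compound 4 `CN1C(=O)C(c2ccccc2Br)N(C)c2nc(Nc3ccc(S(N)(=O)=O)cc3)ncc21` differs from compound 1 in one place: 2-bromophenyl in place of 4-fluorophenyl on a saturated ring carbon. For the measured compounds named here, two measured steps bear on this change. a 1.5-fold higher number from compound 1 to compound 2 (0.18 log units; within the scatter) shows one aryl swap that hardly mattered, whereas a 35-fold lower number from compound 1 to compound 3 (1.54 log units; beyond the scatter) shows that 2-ethylphenyl brought a large gain. Because compound 3 reached 51 nM with 2-ethylphenyl, and 2-bromophenyl resembles it in carrying a single group in the same ring position, a large lowering is expected, estimated as an 18-fold lower number from compound 1 to compound 4 (1.25 log units; beyond the scatter). Compound 4 is therefore expected to give about 100 nM, within 30 nM to 400 nM.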

Compound 4, half-maximal inhibitory concentration: 57 nM
Compound 4: middle estimate off by 1.8-fold (0.24 log units), on the high side; the measured number falls inside the stated range.
By their numbers in this assay, from the lowest: compounds 3 and 4 (each within the scatter of the next); then compounds 1 and 2 (each within the scatter of the next).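

The large gain is not tied to 2-ethylphenyl, since 2-bromophenyl brings one too (a 31-fold lower number from compound 1 to compound 4 (1.49 log units; beyond the scatter) and a 48-fold lower number from compound 2 to compound 4 (1.68 log units; beyond the scatter)). Bromo in place of ethyl on the aromatic carbon leaves the number within the scatter (a 1.1-fold higher number from compound 3 to compound 4 (0.05 log units; within the scatter)), so two different single groups give the same result in these compounds. Nothing measured here explains this.

From the compounds shown here alone, whether a methoxy group, an amine or a carboxylic acid in place of the bromo would hold the number as low stays open. So does how a plain phenyl group would compare.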